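Alkyne arm replaced by a methoxypyridyl group: clearance outlook

This account rests on a few compounds, and the source may have more. Where it says the series, first, only, none or still open, it means among the compounds named here.

Compound 1 `Nc1ccc(S(=O)(=O)N2CCN(c3ncc(C(O)(C(F)(F)F)C(F)(F)F)cc3C#CC3CC3)CC2)cn1` carries a 2-cyclopropylethynyl group on the shared core. In an ADME assay (liver) for metabolic stability, with Liver microsome (Homo sapiens) as the target, using microsomes and NADPH, with a stated time of 30 min, tested at 1 uM (a higher number here means faster removal of the compound, a lower number slower removal), compound 1 gives only a limit of the assay, < 14 mL.min-1.g-1. Compound 2 `Nc1ccc(S(=O)(=O)N2CCN(c3ncc(C(O)(C(F)(F)F)C(F)(F)F)cc3C#CCCO)CC2)cn1` also gives only a limit in this assay, < 14 mL.min-1.g-1. Compound 3 `Nc1ccc(S(=O)(=O)N2CCN(c3ncc(C(O)(C(F)(F)F)C(F)(F)F)cc3-c3cncc(F)c3)CC2)cn1` gives a number in this assay, 24 mL.min-1.g-1. Because the limit of < 14 mL.min-1.g-1 in this assay, at which 2 of the 3 values shown sit, holds compounds 1 and 2 alike, the step that the two limits leave unreadable from compound 1 to compound 2 cannot be read. The step of an at least 1.7-fold higher number from compound 1 to compound 3 (0.23 log units; that floor lies within the scatter) and the step of an at least 1.7-fold higher number from compound 2 to compound 3 (0.23 log units; that floor lies within the scatter) both run from a limit to a measured number, so only their floors are known.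

Compound 4 `COc1cncc(-c2cc(C(O)(C(F)(F)F)C(F)(F)F)cnc2N2CCN(S(=O)(=O)c3ccc(N)nc3)CC2)c1` differs from compound 1 by 5-methoxypyridin-3-yl in place of 2-cyclopropylethynyl on an aromatic carbon. The measured step that bears on this change is an at least 1.7-fold higher number from compound 1 to compound 3 (0.23 log units; that floor lies within the scatter), where a six-membered aromatic ring with one hetero atom likewise enters on the same aromatic carbon in place of the 2-cyclopropylethynyl group. The expectation in this assay is therefore a rise, and the estimated step is an at least 2.1-fold higher number from compound 1 to compound 4 (0.33 log units; beyond the scatter), of at least the size seen in the step of an at least 1.7-fold higher number from compound 1 to compound 3 (0.23 log units; that floor lies within the scatter). Compound 4 is estimated at 30 mL.min-1.g-1 in this assay, with a range from 14 mL.min-1.g-1 to 70 mL.min-1.g-1.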

Compound 4, intrinsic clearance in microsomes: 44 mL.min-1.g-1
For compound 4 the middle estimate is 1.5-fold (0.17 log units) below the measured one, and the stated range covers the measured number.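

In this assay, the exchange of the alkyne arm for a substituted pyridin-3-yl group on this aromatic carbon, ortho to a large group, now gives a step that is beyond the scatter even at its floor: an at least 3.1-fold higher number from compound 1 to compound 4 (0.49 log units; beyond the scatter), and likewise an at least 3.1-fold higher number from compound 2 to compound 4 (0.49 log units; beyond the scatter). Within the data shown here, the earlier floors, set by compound 3, lay within the scatter, so compound 4 is the first clear sign that this change raises the number, whichever of the two alkyne arms leaves. The swap on the pyridine itself adds no firm difference, since a 1.8-fold higher number from compound 3 to compound 4 (0.26 log units; within the scatter) lies within the scatter, and methoxy and fluoro cannot be told apart here.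

The true values of the two alkyne compounds, and with them the full size of these steps and the step from compound 1 to compound 2, cannot be read because both compounds sit at one limit: the limit of < 14 mL.min-1.g-1 in this assay, at which 2 of the 4 values shown sit. Also open, on these data alone, is whether a dimethylamino group or a carboxylic acid in place of the methoxy of compound 4 would stay with compounds 3 and 4 or move toward the alkyne compounds in this assay.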